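The source may hold more compounds than are shown below. What is called first, only, known or untested is meant among the compounds shown, and "the series" means these compounds.

Measured in a physicochemical assay for solubility, with a stated time of 24 h, tested at 30 mg/mL; on this read-out lower numbers stand for lower solubility and higher numbers for higher solubility:
- compound 1 `Cc1cc(COc2ccc(S(=O)(=O)NC(C)(C)CC(=O)NO)cc2)c2ccccc2n1`: 1600000 nM
- compound 2 `CC(=O)N1CC2(C1)CC(CC(=O)NO)(NS(=O)(=O)c1ccc(OCc3cc(C)nc4ccccc34)cc1)C2`: 3000000 nM
- compound 3 `Cc1cc(COc2ccc(S(=O)(=O)NC3(CC(=O)NO)CCN(C(=O)CC(C)C)C3)cc2)c2ccccc2n1`: 17000000 nM; 7900000 nM (2 entries)

Compound 1 lies within the scatter of compound 2, and the numbers of both stand lower than the several entries of compound 3 in this assay, 17000000 nM; 7900000 nM (2 entries).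

The next step leads to compound 4 `Cc1cc(COc2ccc(S(=O)(=O)NC3(C(=O)NO)CCCCC3)cc2)c2ccccc2n1`, which keeps the shared core and changes the group on a sulfonamide nitrogen: a group of 10 heavy atoms (7 carbon, 1 nitrogen, 2 oxygen; one six-membered non-aromatic ring of carbon only) in place of a group of 8 heavy atoms (5 carbon, 1 nitrogen, 2 oxygen; no ring), on a sulfonamide nitrogen. A six-membered non-aromatic ring of carbon only thus enters where compound 1 has no ring.

For the measured compounds named here, no measured pair isolates a comparable step, so the expectation in this assay is indirect. Compound 1 and compound 2 also differ on that nitrogen, and compound 2 gives 3000000 nM, so a change at this place need not move the number beyond the scatter. Compound 3 goes against this reading. A small step towards a lower number is expected, though none beyond the scatter. The estimated change is a 1.6-fold lower number from compound 1 to compound 4 (0.20 log units; within the scatter). For compound 4 the expected value is 1000000 nM, with an estimated range of 300000 nM to 3000000 nM.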

Compound 4, solubility: 11000000 nM
The estimate for compound 4 lay 11-fold (1.04 log units) below the measured number, and the stated range ends below it.
By their numbers in this assay, from the lowest: compounds 1 and 2 (each within the scatter of the next); then compound 4.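

In this assay, for the compounds shown here, the only step that can be read lies on the sulfonamide nitrogen: a group of 10 heavy atoms with one six-membered non-aromatic ring of carbon only, in place of a group of 8 heavy atoms with no ring, gives a 6.9-fold higher number from compound 1 to compound 4 (0.84 log units; beyond the scatter). Going by these compounds alone, a change at this place can therefore move the number beyond the scatter, which the earlier compounds, with no step between them, could not show. The hydrogen-bond donor and acceptor counts and the net charge of the two groups are the same, so the step comes with no change in those counts.

This single step does not separate the ring from the added heavy atoms. An open carbon chain on the sulfonamide nitrogen, or a six-membered ring carrying an amine, would bear on that question.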